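Adding ethyl to the core of compound 3

The source may hold more compounds than are shown below. What is called first, only, known or untested is meant among the compounds shown, and "the series" means these compounds.

Values in a functional assay on ileum (Cavia porcellus) for antagonist activity; a higher number here means a weaker inhibitor, a lower number a stronger inhibitor:
- compound 1 `CCCc1cc(C(C)=O)ccc1OCC(O)COc1ccc2c(O)c([N+](=O)[O-])c(=O)oc2c1`: 700 nM
- compound 2 `CC(=O)c1ccc(OCC(O)COc2ccc3c(O)c([N+](=O)[O-])c(=O)oc3c2)c(C)c1O`: 500 nM
- compound 3 `CCCc1c(OCC(O)COc2ccc3c(O)c([N+](=O)[O-])c(=O)oc3c2)ccc(C(C)=O)c1O`: 80 nM

In this assay, compound 3 gives the lowest number of the three at 80 nM, and its steps to both other compounds lie beyond the scatter. The next change leads to compound 4 `CCCc1c(OCC(O)COc2ccc3c(O)c([N+](=O)[O-])c(=O)oc3c2CC)ccc(C(C)=O)c1O`, with ethyl in place of hydrogen on an aromatic carbon of the shared core: ethyl in place of hydrogen on an aromatic carbon.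

For the measured compounds named here, no measured step alters this carbon, so the precedents are indirect. Hydroxy in place of hydrogen on an aromatic carbon gave an 8.8-fold lower number from compound 1 to compound 3 (0.94 log units; beyond the scatter), but it is a different group at a different place. The closer precedent is ethyl in place of hydrogen on a saturated chain carbon bound to an aromatic carbon, which gave a 6.3-fold lower number from compound 2 to compound 3 (0.80 log units; beyond the scatter). That step sits elsewhere in the molecule, so it supports only a cautious expectation of a modest fall in this assay, and no change beyond the scatter remains possible.

The expected step is a 1.8-fold lower number from compound 3 to compound 4 (0.25 log units; within the scatter). For compound 4 the estimated value is 45 nM, with an expected range of 12 nM to 170 nM.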

Compound 4, half-maximal inhibitory concentration: 50 nM
Compound 4: the middle estimate sits 1.1-fold (0.05 log units) below what was measured, within the range that was stated.
By their numbers in this assay, from the lowest: compounds 4 and 3 (each within the scatter of the next); then compounds 2 and 1 (each within the scatter of the next).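

In this assay, ethyl in place of hydrogen on an aromatic carbon of the shared core gives a 1.6-fold lower number from compound 3 to compound 4 (0.20 log units; within the scatter) and so leaves the read-out inside the scatter at this carbon, ortho to a large group. For the compounds shown here, the steps among compounds 1, 2 and 3 all lie outside the shared core, so this step is the only reading of a change on the core itself. No data on any other property bear on this result.

Ethyl is the only group read at this carbon, so a methoxy group, an amine, a carboxylic acid or a longer chain there could give a different outcome. Going by these compounds, whether ethyl at this carbon would give the same result on the cores of compound 1 and compound 2, which lack the features of compound 3, also stays open.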